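Spiro-amide series: opening the hydroxyethylpiperidine amide

A few compounds are considered here, and "the series" means these few. Any claim that something is new, unique, unknown or untested is made for them only; others in the source may bear on it.

Two compounds have numbers in an assay on HEK293 cells for displacement of a labelled ligand from NPC1-like intracellular cholesterol transporter 1 (Homo sapiens); a higher number here means a weaker inhibitor, a lower number a stronger inhibitor. Compound 1 `O=C(CN1CN(c2ccccc2)C2(CCN(C(=O)c3ccc(C4CCCCC4)cc3)CC2)C1=O)N1CCC(CO)CC1` gives 1100 nM. Compound 2 `CC(C)(C)c1ccc(C(=O)N2CCC3(CC2)C(=O)N(CC(=O)N2CCCCC2CCO)CN3c2ccccc2)cc1` gives 6100 nM, the higher of the two numbers, lying beyond the scatter from compound 1. Within the data shown here, no pair differing in a single place has been measured, so no step size is yet known. Compound 3 `CC(C)(C)c1ccc(C(=O)N2CCC3(CC2)C(=O)N(CC(=O)NCCCCCO)CN3c2ccccc2)cc1` carries (5-hydroxypentyl)amino in place of 2-(2-hydroxyethyl)piperidin-1-yl on a carbonyl carbon. Compound 3 remains unmeasured, and with no comparable step shown, the expected step of a 1.1-fold higher number from compound 2 to compound 3 (0.06 log units; within the scatter) is none beyond the scatter, in either direction. Compound 3 is estimated at 7000 nM, within 2500 nM to 20000 nM.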

Compound 3, half-maximal inhibitory concentration: 9400 nM
Beside the measured number, compound 3's estimate is 1.3-fold (0.13 log units) below it, and the stated range covers the measured number.
By their numbers in this assay, from the lowest: compound 1; then compounds 2 and 3 (each within the scatter of the next).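

With (5-hydroxypentyl)amino in place of 2-(2-hydroxyethyl)piperidin-1-yl on a carbonyl carbon, this assay gives a 1.5-fold higher number from compound 2 to compound 3 (0.19 log units; within the scatter) and the two compounds cannot be told apart. At this position, then, the six-membered ring is not needed for a number of this size, and the added hydrogen-bond donor does not separate the pair either. Nothing measured here explains this result.

Still open, going by these compounds, is whether a longer chain, or a carboxylic acid in place of the hydroxyl, would give a step beyond the scatter. Also open, on these data alone, is how the open chain reads with a cyclohexyl group in place of the tert-butyl group.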